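The source may hold more compounds than are shown below. What is called first, only, known or untested is meant among the compounds shown, and "the series" means these compounds.

Measured so far in a functional assay on MCF7 cells (Homo sapiens) for cytotoxicity, read by MTT assay, with a stated time of 48 h; on this read-out lower numbers stand for stronger inhibition and higher numbers for weaker inhibition:
compound 2 `O=C(Nc1ccccc1)c1cn(-c2ccccc2)nc1-c1ccc(Cl)cc1`: 2340 nM
compound 1 `COc1ccc(-c2nn(-c3ccccc3)cc2C(=O)Nc2ccc(Br)cc2)cc1`: 8210 nM

Compound 2 holds the lowest of the two numbers in this assay, and the number of compound 1 lies beyond the scatter above it. Within the data shown here, the two compounds differ in more than one place, so no single step between them can be read.

Compound 3 `O=C(Nc1ccc(Br)cc1)c1cn(-c2ccccc2)nc1-c1ccc(Cl)cc1` is not yet measured. It differs from compound 2 in one place: bromo in place of hydrogen on an aromatic carbon. Compound 1 also carries a bromo on its anilide and gives the higher number, but it differs from compound 2 in a second place as well, so its value cannot be carried over to compound 3.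

For compound 3 a small shift toward a higher number, or none beyond the scatter, is expected: a 1.5-fold higher number from compound 2 to compound 3 (0.17 log units; within the scatter). The estimate for compound 3 in this assay is 3500 nM, with a range from 1200 nM to 10000 nM.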

Compound 3, half-maximal inhibitory concentration: 5310 nM
Compound 3: middle estimate off by 1.5-fold (0.18 log units), on the low side, and the stated range covers the measured number.
By their numbers in this assay, from the lowest: compound 2; then compounds 3 and 1 (each within the scatter of the next).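

In this assay bromo in place of hydrogen on an aromatic carbon, para to a large group, gives a 2.3-fold higher number from compound 2 to compound 3 (0.36 log units; beyond the scatter) and thus shows that this position of the anilide responds to substitution, which the two earlier compounds, differing in two places, could not show. With that bromo held constant, chloro in place of methoxy on the other aromatic ring gives a 1.5-fold lower number from compound 1 to compound 3 (0.19 log units; within the scatter) and stays within the scatter, so this exchange separates the two compounds by no readable amount. Nothing measured here explains the step at the bromo position.

On these data alone, whether the shift is particular to bromo or follows from any group on this carbon remains open, as a fluoro, a methyl or an amine there would tell. Also open, as far as these compounds go, is whether a carboxylic acid at this place would move the number the other way.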